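Butyl for ethylsulfanyl at the shared core

A few compounds are considered here, and "the series" means these few. Any claim that something is new, unique, unknown or untested is made for them only; others in the source may bear on it.

The series rests on a shared core, varied at one aromatic carbon. Compound 1 `CNc1nc(N)c2nc(O)n(Cc3ccccc3)c2n1` gives 1 uM in a functional assay (spleen, spleen) for activation, with Mus musculus as the target; a lower number here means that less compound is needed, a higher number that more compound is needed for the effect; compound 2 `Nc1nc(O)nc2c1nc(O)n2Cc1ccccc1` gives 0.1 uM; compound 3 `CCSc1nc(N)c2nc(O)n(Cc3ccccc3)c2n1` gives 0.1 uM. Compound 3 thus stands level with compound 2, and the two share the lowest number of the three, with compound 1 the furthest away, as a 10-fold lower number from compound 1 to compound 3 (1.00 log units; beyond the scatter) shows.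

Compound 4 `CCCCc1nc(N)c2nc(O)n(Cc3ccccc3)c2n1` differs from compound 3 in one place: butyl in place of ethylsulfanyl on an aromatic carbon. For the measured compounds named here, no measured step exchanges these two groups. What bears on it is that the site accepts unlike groups without change, as in no change at the digits printed from compound 2 to compound 3 (within the scatter), whereas a 10-fold lower number from compound 1 to compound 2 (1.00 log units; beyond the scatter) and a 10-fold lower number from compound 1 to compound 3 (1.00 log units; beyond the scatter) show that methylamino alone stands apart. The step into compound 4 is therefore expected to stay within the scatter, as a 2.0-fold higher number from compound 3 to compound 4 (0.30 log units; within the scatter). Compound 4 is estimated at 0.2 uM, within 0.05 uM to 1 uM.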

Compound 4, minimum effective concentration: 0.03 uM
The estimate for compound 4 lay 6.7-fold (0.82 log units) above the measured number; measured number below the stated range.
By their numbers in this assay, from the lowest: compound 4; then compounds 2 and 3 (each within the scatter of the next); then compound 1.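

In this assay, for the compounds shown here, the site proves more than merely tolerant: butyl gives a 3.3-fold lower number from compound 3 to compound 4 (0.52 log units; beyond the scatter) and a 3.3-fold lower number from compound 2 to compound 4 (0.52 log units; beyond the scatter), separating groups that the earlier compounds had left level. The butyl chain carries no sulfur and no hydrogen-bond acceptor, so neither is required at this aromatic carbon for the lowest number of the four, and the contrast with methylamino grows to a 33-fold lower number from compound 1 to compound 4 (1.52 log units; beyond the scatter). The data offer no explanation for this gain.

The compounds shown leave open whether a hexyl chain, a branched isobutyl group or a phenyl ring at this carbon would lower the number further or reverse the gain. They also leave open whether butyl would give a similar step if the benzyl group on the shared core were replaced by another group, such as methyl.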